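From 2-bromophenyl to 3-bromophenyl on the sulfur-bound chain carbon

The compounds below may be only part of what the source reports. "The series", "measured", "known", "first", "only" and "open" are said of these compounds alone.

In a functional assay on BGC-823 cells (Homo sapiens) for antiproliferative activity, read by MTT assay, with a stated time of 24 h (a higher number here means a weaker inhibitor, a lower number a stronger inhibitor), compound 2 (`Brc1ccccc1CSc1nnc(-c2ccc3c(c2)OCCO3)n1-c1ccccc1`) gives > 100000 nM, which is a limit of the assay and not a number. Compound 1 (`O=[N+]([O-])c1cccc(CSc2nnc(-c3ccc4c(c3)OCCO4)n2-c2ccccc2)c1`) gives 30100 nM in this assay. Compound 3 (`Brc1cccc(CSc2nnc(-c3ccc4c(c3)OCCO4)n2-c2ccccc2)c1`) has not yet been measured. Its difference from compound 2 is 3-bromophenyl in place of 2-bromophenyl on a saturated chain carbon bound to a sulfur. Here 3-bromophenyl replaces 2-bromophenyl on a saturated chain carbon bound to a sulfur, and the new name shares its number with the 3-nitrophenyl of compound 1. Going by the values given here, one measured step bears on this: an at least 3.3-fold higher number from compound 1 to compound 2 (0.52 log units; beyond the scatter). Among the compounds with values here, that step changes the group as well as its place, and no measured pair isolates the bromine shift, so it offers only partial guidance. A modest move towards a lower number, meaning a stronger inhibitor, is expected. The expected step is an at least 2.2-fold lower number from compound 2 to compound 3 (0.34 log units; beyond the scatter). For compound 3 the estimate is 45000 nM, with an expected range of 15000 nM to 100000 nM.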

Compound 3, half-maximal inhibitory concentration: 65600 nM
Compound 3: middle estimate off by 1.5-fold (0.16 log units), on the low side; the measured number falls inside the stated range.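

In this assay, the change from 2-bromophenyl to 3-bromophenyl gives an at least 1.5-fold lower number from compound 2 to compound 3 (0.18 log units; that floor lies within the scatter), so this pair does not establish a real gain from the bromine shift. Compound 2 stands at a limit of the assay and not at a number: the limit of > 100000 nM in this assay, at which 1 of the 3 values shown sits. Bromo in place of nitro on an aromatic carbon gives a 2.2-fold higher number from compound 1 to compound 3 (0.34 log units; beyond the scatter), a modest step that separates the group from its place, which the step from compound 1 to compound 2 could not do.

The compounds shown do not tell whether the lower number with 3-nitrophenyl is particular to nitro or extends to other groups, such as an amine or a carboxylic acid on the same ring. From the compounds shown here alone, the effect of a longer chain between the sulfur and the ring also remains open.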